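The compounds below may be only part of what the source reports. "The series", "measured", "known", "first", "only" and "open" are said of these compounds alone.

All three numbers so far come from an assay on CHO cells for agonist activity at 5-hydroxytryptamine receptor 1D (Homo sapiens), read by GTPgammaS binding; on this read-out lower numbers stand for an effect already at smaller amounts and higher numbers for an effect only at larger amounts of compound:

compound 1, `OC[C@H](NC1CCN(CCCc2c[nH]c3ccc(-n4ccnc4)cc23)CC1)c1ccccc1`: 0.8 nM
compound 2, `OC[C@H](NC1CCN(CCCc2c[nH]c3ccc(Cn4cncn4)cc23)CC1)c1ccccc1`: 32 nM
compound 3, `COC[C@H](NC1CCN(CCCc2c[nH]c3ccc(Cn4cncn4)cc23)CC1)c1ccc(F)cc1`: 8.9 nM

Compound 2 stands highest of the three. The nearest neighbour is reached by the step of a 3.6-fold lower number from compound 2 to compound 3 (0.56 log units; beyond the scatter); the furthest lies at the other end of the step of a 40-fold higher number from compound 1 to compound 2 (1.60 log units; beyond the scatter).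

Compound 4, `OC[C@H](NC1CCN(CCCc2c[nH]c3ccc(-n4cncn4)cc23)CC1)c1ccccc1`, differs from compound 2 in one place: 1H-1,2,4-triazol-1-yl in place of (1H-1,2,4-triazol-1-yl)methyl on an aromatic carbon. Within the data shown here, only one measured step bears on this change. The step of a 40-fold higher number from compound 1 to compound 2 (1.60 log units; beyond the scatter) swapped both the five-membered ring and the linker at the same time, so it does not show how much of that large rise belongs to inserting the methylene alone. The step of a 3.6-fold lower number from compound 2 to compound 3 (0.56 log units; beyond the scatter) touched the amine side and says nothing about this position. Since compound 4 keeps the ring of compound 2 but the direct attachment of compound 1, a lower number than compound 2 is expected, though not necessarily the whole way back, and the expected step is an 11-fold lower number from compound 2 to compound 4 (1.03 log units; beyond the scatter). Compound 4 is therefore estimated at 3 nM, with a range from 0.8 nM to 12 nM.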

Compound 4, half-maximal effective concentration: 7.4 nM
The estimate for compound 4 lay 2.5-fold (0.39 log units) below the measured number; the range from low to high includes it.
By their numbers in this assay, from the lowest: compound 1; then compounds 4 and 3 (each within the scatter of the next); then compound 2.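

With the 1H-1,2,4-triazol-1-yl ring kept, removing the methylene alone gives a 4.3-fold lower number from compound 2 to compound 4 (0.64 log units; beyond the scatter) and so accounts for part of the rise seen when ring and linker changed together. With direct attachment to the aromatic carbon kept, changing only the ring gives a 9.3-fold higher number from compound 1 to compound 4 (0.97 log units; beyond the scatter) as well, so each of the two changes matters on its own and neither alone accounts for the whole earlier step. Nothing available here explains why either change has this effect.

Whether a methylene would have a similar effect on the 1H-imidazol-1-yl ring remains open, as (1H-imidazol-1-yl)methyl is not among the compounds shown. Also open, on these data alone, is how this position would respond to a longer chain in place of the methylene, or to an amine in place of the ring.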